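A few compounds are considered here, and "the series" means these few. Any claim that something is new, unique, unknown or untested is made for them only; others in the source may bear on it.

Working notes on the series

Measured so far:
- compound 1, `C[Se]c1ccc(N(C)c2nc(C3CC3)nc3ccccc23)cc1`: in a functional assay on RKO cells (Homo sapiens) for inhibition, read by MTT assay, with a stated time of 48 h (a higher number here means a weaker inhibitor, a lower number a stronger inhibitor), compound 1 gives 21 nM
- compound 2, `COc1ccc(N(C)c2nc(C)nc3ccccc23)cc1[Se]C`: in this assay compound 2 gives 11 nM
- compound 3, `COc1ccc(N(C)c2nc(C)nc3ccccc23)cc1[Se]C#N`: in this assay compound 3 gives 47 nM

Compound 2 and compound 3 share a core and differ in one place, (cyano in place of methyl on a selenium). That change gives a 4.3-fold higher number from compound 2 to compound 3 (0.63 log units; beyond the scatter), a step that lies beyond the usual scatter of repeated measurements. Compound 1 carries a different core from compound 2; the difference between the two cores is not broken down here. Their values in this assay lie within the scatter of each other, so no order between compound 1 and compound 2 is read from them. Compound 1 and compound 3 are further apart, with compound 3 giving the higher number by a margin beyond the scatter.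

Compound 4, `CN(c1ccc([Se]C#N)cc1)c1nc(C2CC2)nc2ccccc12`, is not yet measured in this assay. It differs from compound 1 by cyano in place of methyl on a selenium. The place of the change is described in the same words for both pairs, so this is the same change as that from compound 2 to compound 3, now made on the core of compound 1. For the measured compounds named here, with only one measured instance of this change, the expectation rests on that single step: the step from compound 1 to compound 4 is estimated as a 4.3-fold higher number from compound 1 to compound 4 (0.63 log units; beyond the scatter), set beside a 4.3-fold higher number from compound 2 to compound 3 (0.63 log units; beyond the scatter). On that basis compound 4 is expected to give about 90 nM in this assay, with an estimated range from 40 nM to 200 nM.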

Compound 4, half-maximal inhibitory concentration: 51 nM
For compound 4 the middle estimate is 1.8-fold (0.25 log units) above the measured one; measured number inside the range.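

On the core of compound 1, cyano in place of methyl on a selenium gives a 2.4-fold higher number from compound 1 to compound 4 (0.39 log units; beyond the scatter) in this assay, a step beyond the scatter in the same direction as the one already seen on the core of compound 2. The two steps do not differ in size by more than the scatter allows: the same change on two cores in this assay, a 4.3-fold higher number (0.63 log units; beyond the scatter) from compound 2 to compound 3 and a 2.4-fold higher number (0.39 log units; beyond the scatter) from compound 1 to compound 4, 1.8-fold (0.25 log units) apart, within the scatter of two such steps. So in this series the change carries from one core to the other with its direction kept and no detectable difference in size, but this rests on two pairs in a single assay and shows neither that it would hold on a further core nor why the number rises.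

The compounds shown leave open how the number responds to other groups on the selenium, such as ethyl, a longer chain or benzyl, and whether the same step appears with a sulfur atom in place of the selenium. They also leave open whether a group such as an amine or a carboxylic acid elsewhere on the shared core would alter the size of the step.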